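A few compounds are considered here, and "the series" means these few. Any claim that something is new, unique, unknown or untested is made for them only; others in the source may bear on it.

Compound 1 `CCCCCC/N=C/N1CCC(C(c2ccccc2)c2ccccc2)CC1`: 15 mg/kg
Compound 2 `CCCCCCC/N=C/N1CCC(C(c2ccccc2)c2ccccc2)CC1`: 33.4 mg/kg

In a functional assay on the whole organism (stomach) with Rattus norvegicus as the target (a higher number here means that more compound is needed for the effect, a lower number that less compound is needed), compound 2 gives 33.4 mg/kg, the higher of the two numbers, so more of it is needed for the effect than of compound 1. Compound 3 `CCCCCCCC/N=C/N1CCC(C(c2ccccc2)c2ccccc2)CC1` has not been measured yet. It differs from compound 2 by methyl in place of hydrogen on a saturated chain carbon, seven bonds along the chain from a double-bonded nitrogen. Among the measured compounds shown here, only one measured step bears on this change, the same swap made six bonds along the chain: a 2.2-fold higher number from compound 1 to compound 2 (0.35 log units; beyond the scatter). That step is modest, and a single step cannot establish a trend, so the uncertainty is wide. A further rise of similar size is expected in this assay, as the estimated step shows: a 1.8-fold higher number from compound 2 to compound 3 (0.25 log units; within the scatter). The expected value for compound 3 is 60 mg/kg, with an estimated range of 28 mg/kg to 130 mg/kg.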

Compound 3, dose for half-maximal effect: 176 mg/kg
The estimate for compound 3 lay 2.9-fold (0.47 log units) below the measured number; the whole stated range lies below it.
By their numbers in this assay, from the lowest: compound 1; then compound 2; then compound 3.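

In this assay the methyl added on a saturated chain carbon, seven bonds along the chain from a double-bonded nitrogen, gives a larger rise (a 5.3-fold higher number from compound 2 to compound 3 (0.72 log units; beyond the scatter)) than the same swap six bonds along the chain (a 2.2-fold higher number from compound 1 to compound 2 (0.35 log units; beyond the scatter)). Over both additions the change amounts to ethyl in place of hydrogen (a 12-fold higher number from compound 1 to compound 3 (1.07 log units; beyond the scatter)), so across these three compounds the dose needed climbs with each added carbon, none goes against this, and the climb has not levelled off. Nothing available explains why the second step is the larger one.

Three compounds cannot show whether a still longer chain would keep raising the dose needed or whether the rise would stop. They also leave open how an amine or a carboxylic acid in place of the added methyl would compare.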